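A few compounds are considered here, and "the series" means these few. Any claim that something is new, unique, unknown or untested is made for them only; others in the source may bear on it.

Working notes on the series.

Three compounds carry numbers in an assay for binding affinity to leukotriene B4 receptor 1 (Homo sapiens); on this read-out lower numbers stand for stronger inhibition and higher numbers for weaker inhibition. Compound 1 `CCCCCCCCCCOc1ccc(CC(O)c2cccc(C(=O)O)c2)nc1CCC(=O)O` gives 429 nM in this assay. Compound 2 `COc1ccc(CCCCCCCCOc2ccc(CSc3cccc(C(=O)O)c3)nc2/C=C/C(=O)O)cc1` gives 80 nM. Compound 3 `COc1ccc(CCCCCCCCOc2ccc(CSc3cccc(NS(=O)(=O)C(F)(F)F)c3)nc2/C=C/C(=O)O)cc1` gives 284 nM. Compound 2 stands lowest of the three: compound 3 is nearest, and compound 1 is furthest, both beyond the scatter. Compounds 1 and 2 differ in several places at once, so their two values are only read side by side. Among the measured compounds shown here, the one single-point step is a 3.6-fold higher number from compound 2 to compound 3 (0.55 log units; beyond the scatter); the carboxy on the aromatic carbon was lost there and the number rose by a modest margin.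

Compound 4 `COc1ccc(CCCCCCCCOc2ccc(C[S+]([O-])c3cccc(OC)c3)nc2/C=C/C(=O)O)cc1` is not yet measured. It differs from compound 2 by a group of 10 heavy atoms (7 carbon, 2 oxygen, 1 sulfur; one six-membered aromatic ring of carbon only) in place of a group of 10 heavy atoms (7 carbon, 2 oxygen, 1 sulfur; one six-membered aromatic ring of carbon only), on a saturated chain carbon bound to an aromatic carbon. The leaving group is the (3-carboxyphenyl)sulfanyl of compound 2; the entering group keeps the ring and the same atom count but has no hydrogen-bond donor. The step from compound 2 to compound 3 bears on this, as it also removed the carboxy and weakened this assay; here the carboxy goes without any acidic replacement, so a step of at least that size is expected, toward weaker affinity, a 5.0-fold higher number from compound 2 to compound 4 (0.70 log units; beyond the scatter). Compound 4 is therefore estimated at 400 nM, with a range from 150 nM to 1200 nM.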

Compound 4, inhibition constant: 232 nM
Estimate against measurement, compound 4: 1.7-fold (0.24 log units) above; measured number inside the range.
By their numbers in this assay, from the lowest: compound 2; then compounds 4, 3 and 1 (each within the scatter of the next).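

In this assay, the exchange on a saturated chain carbon bound to an aromatic carbon gives a 2.9-fold higher number from compound 2 to compound 4 (0.46 log units; beyond the scatter), so an entering group with the same heavy-atom count and the same aromatic ring, but with no hydrogen-bond donor, does not match the (3-carboxyphenyl)sulfanyl group. Alongside a 3.6-fold higher number from compound 2 to compound 3 (0.55 log units; beyond the scatter), this gives two changes that remove the carboxy, one on the aromatic carbon and one through exchange of the whole group, and both move to a higher number beyond the scatter, with neither reaching the value of compound 2 at 80 nM. No supporting data bear on why the number rises at this position.

The exchange alters the sulfur link and the ring substituent together, so the share of each in the step cannot be read from the compounds shown. A carboxylic acid on the ring with the sulfinyl link of compound 4, or a methoxy on the ring with the sulfanyl link of compound 2, would separate the two changes.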